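The compounds below may be only part of what the source reports. "The series", "measured", "known", "first", "only" and "open" are said of these compounds alone.

Three measured members of the series share one core: compound 1 `CCc1ccc(C(=O)Nc2cccc(NC(=O)COc3ccc4c(=O)ccoc4c3)c2)cc1`, compound 2 `O=C(COc1ccc2c(=O)ccoc2c1)Nc1cccc(NC(=O)c2ccc([N+](=O)[O-])cc2)c1` and compound 3 `COC(=O)c1ccc(C(=O)Nc2cccc(NC(=O)COc3ccc4c(=O)ccoc4c3)c2)cc1`. In an assay on isolated protein for inhibition of Rho-associated protein kinase 2 (Homo sapiens), read by scintillation counting, radiometric assay and 33P incorporation, with a stated time of 40 min, in the presence of a further agent that is not named here (a lower number here means a stronger inhibitor, a higher number a weaker inhibitor), compound 1 gives 24 nM, compound 2 gives 15 nM and compound 3 gives 29 nM. Compound 3 thus holds the highest of the three numbers, but every step among them stays within the scatter: a 1.6-fold lower number from compound 1 to compound 2 (0.20 log units; within the scatter), a 1.2-fold higher number from compound 1 to compound 3 (0.08 log units; within the scatter) and a 1.9-fold higher number from compound 2 to compound 3 (0.29 log units; within the scatter). Compound 4 `Cc1nc(C(=O)Nc2cccc(NC(=O)COc3ccc4c(=O)ccoc4c3)c2)cs1` differs from compound 3 by 2-methyl-1,3-thiazol-4-yl in place of 4-(methoxycarbonyl)phenyl on a carbonyl carbon. For the measured compounds named here, no measured step exchanges the whole aryl group, so none bears directly on this change; the measured steps show only that changing the substituent on that ring leaves this assay essentially flat. The expected step of a 1.7-fold higher number from compound 3 to compound 4 (0.24 log units; within the scatter) is therefore set modest and uncertain. For compound 4 the estimate is 50 nM, with a range from 15 nM to 200 nM.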

Compound 4, half-maximal inhibitory concentration: 33 nM
Compound 4: the middle estimate sits 1.5-fold (0.18 log units) above what was measured, and the stated range covers the measured number.
By their numbers in this assay, from the lowest: compounds 2, 1, 3 and 4 (each within the scatter of the next, the first and the last beyond it).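

In this assay, exchanging the whole 4-(methoxycarbonyl)phenyl group on the carbonyl carbon for 2-methyl-1,3-thiazol-4-yl stays within the scatter (a 1.1-fold higher number from compound 3 to compound 4 (0.06 log units; within the scatter)), and the same holds against the 4-ethylphenyl group (a 1.4-fold higher number from compound 1 to compound 4 (0.14 log units; within the scatter)). Only the step from the 4-nitrophenyl group passes the scatter, and modestly (a 2.2-fold higher number from compound 2 to compound 4 (0.34 log units; beyond the scatter)), so among these compounds this position accepts a five-membered aromatic ring with hetero atoms as well as a six-membered carbon ring. No measurement at hand offers an explanation for this.

Open, from the compounds shown here alone, is whether a non-aromatic group on that carbonyl carbon, such as a cyclohexyl ring or a primary amine, would stay in this range. Also open, going by these compounds, is whether a carboxylic acid on the phenyl ring would do so.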